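Removing a methoxy group from a triazine anticancer series

The source may hold more compounds than are shown below. What is called first, only, known or untested is meant among the compounds shown, and "the series" means these compounds.

Measured compounds:
- compound 1 `COc1ccc(Nc2nnc(Cl)c(Nc3cc(OC)c(OC)c(OC)c3)n2)cc1`: 22300 nM
- compound 2 `COc1cccc(Nc2nnc(Cl)c(Nc3cc(OC)c(OC)c(OC)c3)n2)c1`: 15900 nM
- compound 3 `COc1cc(Nc2nc(Nc3ccc(Br)cc3)nnc2Cl)cc(OC)c1OC`: 41600 nM

These three compounds share a core and were tested in a functional assay on ECa-109 cells for inhibition, with ECa-109 cell line (Homo sapiens) as the target, read by MTT assay, with a stated time of 48 h; a higher number here means a weaker inhibitor, a lower number a stronger inhibitor. Among them compound 1 gives the second highest of the three numbers; its nearest neighbour is compound 2, at a 1.4-fold lower number from compound 1 to compound 2 (0.15 log units; within the scatter), and the furthest is compound 3, at a 1.9-fold higher number from compound 1 to compound 3 (0.27 log units; within the scatter). Within the data shown here, only the step of a 2.6-fold higher number from compound 2 to compound 3 (0.42 log units; beyond the scatter) reaches beyond the scatter.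

Compound 4 `COc1cc(Nc2nc(Nc3ccccc3)nnc2Cl)cc(OC)c1OC` is not yet measured. It differs from compound 1 in one place: hydrogen in place of methoxy on an aromatic carbon. The step to compound 3, which also replaces the methoxy group on that same aromatic carbon, stayed within the scatter, and the step to compound 2, which moves the methoxy group, stayed within the scatter as well. Both point to a small change. Compound 4 is therefore expected to show a 1.2-fold higher number from compound 1 to compound 4 (0.07 log units; within the scatter), with an estimate of 26000 nM and a range from 12000 nM to 55000 nM.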

Compound 4, half-maximal inhibitory concentration: 12600 nM
Compound 4: middle estimate off by 2.1-fold (0.31 log units), on the high side; the range from low to high includes it.
By their numbers in this assay, from the lowest: compounds 4, 2, 1 and 3 (each within the scatter of the next, the first and the last beyond it).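

Read in this assay, the unsubstituted phenyl of compound 4 shows that the methoxy group can be removed altogether without a change beyond the scatter, with a 1.8-fold lower number from compound 1 to compound 4 (0.25 log units; within the scatter) for the 4-methoxyphenyl group and a 1.3-fold lower number from compound 2 to compound 4 (0.10 log units; within the scatter) for the 3-methoxyphenyl group. Hydrogen in place of bromo is different: a 3.3-fold lower number from compound 3 to compound 4 (0.52 log units; beyond the scatter) is the first step at this position to reach beyond the scatter, so here hydrogen and bromo can be told apart, while hydrogen and methoxy cannot. Nothing measured on these compounds gives a reason for this difference.

The compounds shown leave open whether an amine, a carboxylic acid or a fluoro group on this aromatic carbon would stay close to compound 4 or move as far as bromo does. They also leave open whether a longer chain such as ethoxy would be tolerated here as well as methoxy.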